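Replacing cyano with methyl on compound 3

A few compounds are considered here, and "the series" means these few. Any claim that something is new, unique, unknown or untested is made for them only; others in the source may bear on it.

- compound 1 `COc1ccc(C)cc1NC(=S)N/N=C/c1ccc2ccccc2n1` gives > 100000 nM (a limit, not a number)
- compound 2 `NC(=S)N/N=C/c1cc2cccnc2s1` gives 100000 nM
- compound 3 `N#Cc1ccc(NC(=S)N/N=C/c2ccc3ccccc3n2)cc1` gives 23700 nM

All three values come from a functional assay on SGC-7901 cells (Homo sapiens) for antiproliferative activity, read by sulforhodamine B assay, with a stated time of 72 h (a lower number here means a stronger inhibitor, a higher number a weaker inhibitor), and compound 3 holds the lowest of the two true numbers there, with compound 2 higher by a gap beyond the usual scatter. Compound 4 `Cc1ccc(NC(=S)N/N=C/c2ccc3ccccc3n2)cc1` carries methyl in place of cyano on an aromatic carbon, para to a large group (methyl in place of cyano on an aromatic carbon). For the measured compounds named here, no measured pair shows this change alone, so any forecast stays loose. Compound 1, which also carries a methyl group, reads > 100000 nM and this is a limit. Starting from compound 3 at 23700 nM a move toward a higher number is expected in this assay, an estimated 1.7-fold higher number from compound 3 to compound 4 (0.23 log units; within the scatter) of modest size. Compound 4 is estimated at 40000 nM with an expected range of 12000 nM to 100000 nM in this measurement.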

Compound 4, half-maximal inhibitory concentration: 92900 nM
For compound 4 the middle estimate is 2.3-fold (0.37 log units) below the measured one; measured number inside the range.
By their numbers in this assay, from the lowest: compound 3; then compounds 4 and 2 (each within the scatter of the next).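

In this assay, for the compounds shown here, changing 4-cyanophenyl to 4-methylphenyl gives a 3.9-fold higher number from compound 3 to compound 4 (0.59 log units; beyond the scatter), the first comparison here that isolates a single change, and it shows that the group at this place matters. Of the two groups, cyano gives the lower number. Compound 1 also carries a methyl group but differs in other ways, and its reading is only a limit: the limit of > 100000 nM in this assay, at which 1 of the 4 values shown sits.

On these data alone, whether an amine, a carboxylic acid or a longer chain at this place would give a lower number than cyano remains open. So does whether this change would have a similar effect on a different core.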